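The source may hold more compounds than are shown below. What is called first, only, known or untested is meant among the compounds shown, and "the series" means these compounds.

Measured so far:
compound 1, `O=C(/C=C1\CCc2ccc(F)cc21)NCC1CC1`: 0%
compound 2, `CC(C)NC(=O)/C=C1\CCc2ccc(F)cc21`: 45%

Both compounds were tested in a functional assay on the whole organism with Rattus norvegicus as the target, at a dose of 20 mg/kg by the oral route; on this read-out higher numbers stand for more inhibition at the one dose given (going by the name of the read-out) and lower numbers for less inhibition. Of the two numbers, compound 2 stands highest; its nearest neighbour is compound 1, and the step of a number 45 percentage points higher from compound 1 to compound 2 (beyond the scatter) is the only one recorded. That step shows that the group on the amide-type nitrogen can move the read-out a great deal, although with two compounds nothing wider than that can be claimed.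

Compound 3, `O=C(/C=C1\CCc2ccc(F)cc21)NC1CCC1`, has not been measured yet. It differs from compound 2 by cyclobutyl in place of isopropyl on an amide-type nitrogen. Within the data shown here, the one measured step bears on it only loosely: it changes the same position, and it was large, so a change beyond the scatter is quite possible here too, but it gives no sign of direction for the cyclobutyl group, which is neither of the two groups compared there. A step of a number 15 percentage points lower from compound 2 to compound 3 (beyond the scatter) is therefore expected only tentatively, with a wide range.

For compound 3 the estimate in this assay is 30%, between 5% and 60%.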

Compound 3, a percentage reported as inhibition, in the whole organism at one dose (the size of the read-out at that dose, not a potency): 4%
The estimate for compound 3 lay 26 percentage points above the measured number; the measured number lies below the stated range.
By their numbers in this assay, from the lowest: compounds 1 and 3 (each within the scatter of the next); then compound 2.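

In this assay, cyclobutyl in place of isopropyl on the amide-type nitrogen gives a number 41 percentage points lower from compound 2 to compound 3 (beyond the scatter) and so shows that this position can lose the read-out as well as gain it, even when the group grows only from three carbons with no ring to four carbons in a four-membered ring. Cyclobutyl in place of cyclopropylmethyl gives a number 4 percentage points higher from compound 1 to compound 3 (within the scatter) and leaves those two groups indistinguishable here, so among these three compounds the two groups that carry a ring sit together and only the open, branched isopropyl stands apart. Nothing measured for these compounds explains this sharp difference in the whole animal.

Three groups cannot show whether a ring itself is what matters, or whether other open groups such as tert-butyl, sec-butyl or a longer chain such as n-butyl would match or pass isopropyl. Also open is how this position would respond to a group carrying an amine or a carboxylic acid, and how any of these compounds would behave at other doses, since a single dose gives the size of an effect and not a potency.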